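A few compounds are considered here, and "the series" means these few. Any claim that something is new, unique, unknown or untested is made for them only; others in the source may bear on it.

Working notes on a small series sharing one core, read in a functional assay on HepG2 cells (Homo sapiens) for antiproliferative activity, read by MTT assay, with a stated time of 24 h; a higher number here means a weaker inhibitor, a lower number a stronger inhibitor. Compound 1 `COc1ccc(C(=O)/C=C/c2ccc(-c3ccccc3)cc2)c2c1C=CC(C)(C)O2` gives > 10000 nM, which is a limit of the assay and not a number. Compound 2 `COc1ccc(/C=C/C(=O)c2ccc(OC)c3c2OC(C)(C)C=C3)cn1` gives > 10000 nM, which is likewise a limit. Compound 2 therefore has no number of its own, and its standing is described only by the limit of > 10000 nM in this assay, at which 2 of the 2 values shown sit. Going by the values given here, no step between measured compounds is available, so the size of a single change in this assay cannot be read from the data.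

The next compound is compound 3 `COc1ccc(C(=O)/C=C/c2ccc(Cl)cc2)c2c1C=CC(C)(C)O2`, and the change from compound 2 is 4-chlorophenyl in place of 6-methoxypyridin-3-yl on a double-bonded chain carbon bound to a double-bonded chain carbon. In words, 4-chlorophenyl stands in place of 6-methoxypyridin-3-yl on a double-bonded chain carbon bound to a double-bonded chain carbon.

The expected step that the limit leaves unreadable from compound 2 to compound 3 is none beyond the scatter, with no firm direction. This expectation rests on compound 2 and its limit of > 10000 nM, and equally on (the limit of > 10000 nM in this assay, at which 2 of the 2 values shown sit). A further limit would be the most likely report. Compound 3 is estimated at 15000 nM in this assay, with an expected range of 5000 nM to 50000 nM.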

Compound 3, half-maximal inhibitory concentration: > 10000 nM
Compound 3: no number, only a limit; the forecaster's own chance of this, stated with the estimate: 65%; the middle value does not contradict the limit.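

In this assay compound 3 gives > 10000 nM, which is a limit of the assay and not a number. No step from compound 1 or compound 2 to compound 3 can be read, and all three compounds sit at the same limit: the limit of > 10000 nM in this assay, at which 3 of the 3 values shown sit.

The compounds shown leave open whether any change on the shared core alters the read-out in this assay.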